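Replacing phenylcarbamoyl with (sulfamoylamino)methyl in compound 2

This account rests on a few compounds, and the source may have more. Where it says the series, first, only, none or still open, it means among the compounds named here.

Of the compounds shown here, two with a shared core have been measured so far. Compound 1 `O=C(/C(=N/O)Nc1ccc(F)c(Br)c1)C1CCN(C(=O)NCc2ccccc2)CC1` and compound 2 `O=C(Nc1ccccc1)[C@H]1CC[C@H](C(=O)/C(=N/O)Nc2ccc(F)c(Br)c2)CC1` were both examined in an assay on tissue (HeLa cells) for inhibition of Indoleamine 2,3-dioxygenase 1 (Homo sapiens), with a stated time of 48 h; a lower number here means a stronger inhibitor, a higher number a weaker inhibitor. In this assay compound 1 gives 28 nM, while compound 2 gives 197 nM. Going by the values given here, compound 2 therefore stands at the higher of the two numbers; its only comparator is compound 1, whose number lies lower by a gap beyond the usual scatter. Among the compounds with values here, because the two compounds differ in more than one place, no single structural step connects them, and the pair only shows that the two values are well apart.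

Compound 3 `NS(=O)(=O)NC[C@H]1CC[C@H](C(=O)/C(=N/O)Nc2ccc(F)c(Br)c2)CC1` differs from compound 2 in one place: (sulfamoylamino)methyl in place of phenylcarbamoyl on a saturated ring carbon. Within the data shown here, no measured pair illustrates this kind of exchange, so the direction and size of its effect have no precedent among the compounds at hand. The step of a 2.0-fold lower number from compound 2 to compound 3 (0.29 log units; within the scatter) is expected to be small and toward a lower number, though the uncertainty spans both directions. For compound 3 the estimated value in this assay is 100 nM, with a range from 30 nM to 400 nM.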

Compound 3, half-maximal inhibitory concentration: 21 nM
For compound 3 the middle estimate is 4.8-fold (0.68 log units) above the measured one; the measured number lies below the stated range.
By their numbers in this assay, from the lowest: compounds 3 and 1 (each within the scatter of the next); then compound 2.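

In this assay, (sulfamoylamino)methyl in place of phenylcarbamoyl on a saturated ring carbon gives a 9.4-fold lower number from compound 2 to compound 3 (0.97 log units; beyond the scatter), showing that the group at this position can shift the number beyond the scatter, which compound 1 and compound 2 could not show, as they differ in more than one place. The aromatic ring of the leaving group is also not required for a low number in this series: the entering group has no ring and fewer heavy atoms, yet compound 3 gives 21 nM in this assay. Nothing in the data at hand accounts for the size of this step.

This single exchange changes the whole group at once, so it cannot separate the contribution of the sulfamoylamino unit from that of its methyl link or from the departure of the phenyl ring. A simple aminomethyl group, a carboxylic acid or a longer chain ending in the same sulfamoylamino unit at this ring carbon would help to divide that effect, and how (sulfamoylamino)methyl would behave on the core of compound 1 remains an open question.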